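Carbamoyl to benzyloxycarbonyl: expected effect on permeability

This account rests on a few compounds, and the source may have more. Where it says the series, first, only, none or still open, it means among the compounds named here.

Compound 1 `Cn1cncc1CN1CC(N(CC2CCN(C(=O)NC(C)(C)C)CC2)S(=O)(=O)c2ccccn2)Cc2cc(C#N)ccc21` gives 0.6 10^-6 cm/s in an ADME assay on Caco-2 cells (Homo sapiens) for permeability, in the apical to basolateral direction (on this read-out higher numbers stand for higher permeability and lower numbers for lower permeability), the second highest of the three numbers in hand. Compound 3 `Cn1cnc(S(=O)(=O)N(CCn2cccc2)C2Cc3cc(C#N)ccc3N(Cc3cncn3C)C2)c1` gives 0.3 10^-6 cm/s, which lies within the scatter of the number for compound 1. Compound 2 `Cc1noc(C)c1CN(C1Cc2cc(C#N)ccc2N(Cc2cncn2C)C1)S(=O)(=O)c1ccccn1` gives 8 10^-6 cm/s, a number beyond the scatter above compound 1.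

Compound 4 `Cn1cncc1CN1CC(N(CC2CCN(C(=O)OCc3ccccc3)CC2)S(=O)(=O)c2ccccn2)Cc2cc(C#N)ccc21` differs from compound 1 in one place: benzyloxy in place of (tert-butyl)amino on a carbonyl carbon. Among the measured compounds shown here, no measured pair in this set carries the same change, so its size is not anchored by a precedent. A small rise in this assay is expected, of a size that may not clear the scatter. The step from a 2.5-fold higher number from compound 1 to compound 4 (0.40 log units; beyond the scatter) is the expected outcome. Compound 4 is estimated at 1.5 10^-6 cm/s, with a range from 0.5 10^-6 cm/s to 4.5 10^-6 cm/s.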

Compound 4, apparent permeability: 1 10^-6 cm/s
Estimate against measurement, compound 4: 1.5-fold (0.18 log units) above; measured number inside the range.
By their numbers in this assay, from the lowest: compounds 3, 1 and 4 (each within the scatter of the next, the first and the last beyond it); then compound 2.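

At this position, on a carbonyl carbon whose other neighbour is an amide-type nitrogen in a ring, benzyloxy in place of (tert-butyl)amino gives a 1.7-fold higher number from compound 1 to compound 4 (0.22 log units; within the scatter) in this assay and so stays within the scatter. The loss of the hydrogen-bond donor and the entry of a six-membered aromatic ring leave no readable step on this read-out. No measurement at hand bears on why this is so.

Going by these compounds, whether a primary amine or a carboxylic acid on this carbonyl carbon would give a step beyond the scatter stays open. So does whether this same change gives a similar step on other members of the series.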